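Chalcone Boron Heterocycles: From Thiophene to a Methylphenyl Ketone

The source may hold more compounds than are shown below. What is called first, only, known or untested is meant among the compounds shown, and "the series" means these compounds.

Three compounds sharing one boron-containing core have been examined in a toxicity assay on MCF-10A cells (Homo sapiens) for cytotoxicity, read by MTT assay, with a stated time of 48 h; on this read-out lower numbers stand for stronger inhibition and higher numbers for weaker inhibition. Compound 1 `O=C(/C=C/c1ccc2c(c1)B(O)OC2)c1cccs1` carries a thiophen-2-yl group on its carbonyl carbon and gives 13800 nM. Compound 2 `O=C(/C=C/c1ccc2c(c1)B(O)OC2)c1ccc(OCc2ccccc2)cc1` bears a benzyloxy-substituted phenyl ring at the same carbonyl and gives 23300 nM. Compound 3 `O=C(/C=C/c1ccc2c(c1)B(O)OC2)c1ccc(Cl)c(Cl)c1` carries a dichlorophenyl ring and gives 14900 nM. Compound 1 has the lowest of the three numbers, but its nearest neighbour is compound 3 and its furthest is compound 2, and both gaps lie within the scatter of repeated measurements, so no order among the three can be claimed.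

Compound 4 `Cc1cccc(C(=O)/C=C/c2ccc3c(c2)B(O)OC3)c1` has not yet been measured in this assay. It differs from compound 1 in one place: 3-methylphenyl in place of thiophen-2-yl on a carbonyl carbon. Since every aryl group tried so far, whether five-membered or six-membered, has given a value within the scatter of the others, compound 4 is expected to stay in the same region, and the step of a 1.2-fold higher number from compound 1 to compound 4 (0.06 log units; within the scatter) is estimated to be none beyond the scatter. On that basis compound 4 is estimated at 16000 nM, with a likely range from 8000 nM to 32000 nM.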

Compound 4, half-maximal inhibitory concentration: 15900 nM
Compound 4: middle estimate off by 1.0-fold (0.00 log units), on the high side; low and high end bracket the measured number.
By their numbers in this assay, from the lowest: compounds 1, 3, 4 and 2 (each within the scatter of the next).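

In this assay, going by these compounds alone, the step of a 1.2-fold higher number from compound 1 to compound 4 (0.06 log units; within the scatter) is the first change at this position that can be read directly between two compounds differing in one place. It replaces thiophen-2-yl, a five-membered aromatic ring with 1 hetero atom and 1 hydrogen-bond acceptor, with 3-methylphenyl, a six-membered aromatic ring of carbon only with 0 hydrogen-bond acceptors, yet the step stays within the scatter, so this pair shows that the read-out does not separate these two groups on a carbonyl carbon. No measured evidence bears on this result.

The compounds shown leave open whether any group at this carbonyl carbon can produce a step beyond the scatter, since all four carry an aromatic ring with no net charge there, and a ring bearing an amine or a carboxylic acid, or an open alkyl chain in place of the ring, is not among them. They also leave open how unsubstituted phenyl would compare with 3-methylphenyl, a pair that would isolate the methyl group from the ring itself.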